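The source may report more compounds than this note shows. Statements on the series, on what has been measured and on what is new or still open speak of the compounds shown alone.

Measured compounds:
- Compound 1, `Fc1ccc(Cn2nnc3c(Br)cccc32)cc1`: 1 mL/min/g
- Compound 2, `Clc1ccc(Cn2nnc3c(Br)cccc32)cc1`: 2 mL/min/g

In an ADME assay on microsomes from liver (Mus musculus, strain NMRI) for metabolic stability, tested at 2.5 uM (a higher number here means faster removal of the compound, a lower number slower removal), compound 1 gives 1 mL/min/g, which is the lowest of the two numbers at hand. Its nearest neighbour is compound 2, at 2 mL/min/g, and the step of a 2.0-fold higher number from compound 1 to compound 2 (0.30 log units; within the scatter) stays within the scatter, so the two compounds cannot be told apart on this measurement.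

Compound 3, `Fc1ccc(Cn2nnc3c(Br)cccc32)c(Cl)c1`, is not yet measured. It differs from compound 1 in one place: chloro in place of hydrogen on an aromatic carbon. Within the data shown here, the only measured step that bears on this change is a 2.0-fold higher number from compound 1 to compound 2 (0.30 log units; within the scatter), where a chloro group replaced a fluoro group; in compound 3 a chloro group is added while the fluoro group is kept. On that basis the step of a 2.0-fold higher number from compound 1 to compound 3 (0.30 log units; within the scatter) is expected to be small and upward, not clearly beyond the scatter. Compound 3 is therefore estimated at 2 mL/min/g, with a range from 1 mL/min/g to 4 mL/min/g.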

Compound 3, intrinsic clearance in a liver preparation (reported as CLH), per the amount of preparation that the assay uses: 3 mL/min/g
Compound 3: the middle estimate sits 1.5-fold (0.18 log units) below what was measured; measured number inside the range.
By their numbers in this assay, from the lowest: compounds 1, 2 and 3 (each within the scatter of the next, the first and the last beyond it).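

In this assay, a chloro group on an aromatic carbon, ortho to a large group and meta to a fluoro group, gives a 3.0-fold higher number from compound 1 to compound 3 (0.48 log units; beyond the scatter) in a modest step. This shows that the position can affect the clearance number, which the earlier exchange of fluoro for chloro elsewhere on the ring could not show, since a 2.0-fold higher number from compound 1 to compound 2 (0.30 log units; within the scatter) remained inside the usual variation between repeat measurements. Nothing measured here explains why the number rises with this addition.

The compounds shown leave open whether the rise is specific to chloro or would also appear with a methyl group, a methoxy group or an amine at this position. They also leave open whether adding chloro here would produce a similar step in compound 2.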